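A few compounds are considered here, and "the series" means these few. Any claim that something is new, unique, unknown or untested is made for them only; others in the source may bear on it.

Values measured in an in vitro ADME assay on microsomes from liver (Mus musculus) for pharmacokinetics, read by LC-MS, with a stated time of 10 min, tested at 1 uM (a lower number here means slower removal, a higher number faster removal of the compound), are as follows:
- Compound 1 `CN1C[C@H](C(=O)Nc2ccc(F)cc2)[C@@H](c2ccc(/C=C/C(=O)Nc3ccccc3N)cc2)C1` gives 34 mL/min/kg
- Compound 2 `CN1C[C@H](C(=O)Nc2ccc(C(F)(F)F)cc2)[C@@H](c2ccc(/C=C/C(=O)Nc3ccccc3N)cc2)C1` gives 23 mL/min/kg
- Compound 3 `COc1cccc(NC(=O)[C@H]2CN(C)C[C@@H]2c2ccc(/C=C/C(=O)Nc3ccccc3N)cc2)c1` gives 65 mL/min/kg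

Compound 3 stands level, within the scatter, with compound 1 (a 1.9-fold higher number from compound 1 to compound 3 (0.28 log units; within the scatter)) but higher than compound 2 (a 2.8-fold higher number from compound 2 to compound 3 (0.45 log units; beyond the scatter)) on this clearance scale. Compound 4 `Cc1cc(NC(=O)[C@H]2CN(C)C[C@@H]2c2ccc(/C=C/C(=O)Nc3ccccc3N)cc2)ccc1Cl` carries 4-chloro-3-methylphenyl in place of 3-methoxyphenyl on an amide-type nitrogen. Going by the values given here, no measured step makes this exact exchange. The two steps above exchange the same 3-methoxyphenyl at the same place, so they are the nearest guide, although only one clears the scatter. A modest move to a lower number is therefore expected in this assay (a 1.9-fold lower number from compound 3 to compound 4 (0.27 log units; within the scatter)). The estimate for compound 4 is 35 mL/min/kg and the expected range runs from 17 mL/min/kg to 70 mL/min/kg as a rough guide.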

Compound 4, clearance: 65 mL/min/kg
Compound 4: middle estimate off by 1.9-fold (0.27 log units), on the low side; measured number inside the range.
By their numbers in this assay, from the lowest: compounds 2, 1, 3 and 4 (each within the scatter of the next, the first and the last beyond it).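

In this assay, 4-chloro-3-methylphenyl in place of 3-methoxyphenyl on the amide-type nitrogen leaves the clearance where it was (no change at the digits printed from compound 3 to compound 4 (within the scatter)), so here a group with chlorine and no oxygen reads the same as one with oxygen and no chlorine. Compound 4 also stands level with compound 1 (a 1.9-fold higher number from compound 1 to compound 4 (0.28 log units; within the scatter)), and the gap that compound 3 showed to the 4-(trifluoromethyl)phenyl compound recurs (a 2.8-fold higher number from compound 2 to compound 4 (0.45 log units; beyond the scatter)). Nothing available explains these numbers. From the compounds shown here alone, whether an amine or a carboxylic acid on this phenyl group would shift the clearance remains open.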